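Trading a Methoxy Group on a Quinone-Type Core

The source may report more compounds than this note shows. Statements on the series, on what has been measured and on what is new or still open speak of the compounds shown alone.

Of the compounds shown here, three have been tested in an ADME assay on L1210 cells (Mus musculus) for cytotoxicity, with a stated time of 48 h; a higher number here means a weaker inhibitor, a lower number a stronger inhibitor. Compound 1 `C=C1[C@H](C)CCC[C@]1(C)CC/C(C)=C/CC1=C(O)C(=O)C=C(OC)C1=O` gives 2.4 ug/mL, the second highest of the three numbers. Compound 2 `COC1=CC(=O)C(O)=C(C/C=C(\C)CC[C@@]2(C)CCC=C(C)[C@H]2C)C1=O` gives 2 ug/mL, and compound 3 `CC1=CCC[C@H]2[C@](C)(CC3=C(O)C(=O)C=C(N[C@@H](CO)C(=O)O)C3=O)[C@@H](C)CC[C@]12C` gives 3.8 ug/mL; both of these lie within the scatter of compound 1, so the three measured values cannot be told apart. The next compound, compound 4 `C=C1[C@H](C)CCC[C@]1(C)CC/C(C)=C/CC1=C(O)C(=O)C=C(N[C@@H](C(=O)O)[C@@H](C)O)C1=O`, differs from compound 1 in one place: (1-carboxy-2-hydroxypropyl)amino in place of methoxy on a double-bonded ring carbon. Among the measured compounds shown here, no measured pair shows a single such change, so the size of this step is unknown. Given that compound 3 gives 3.8 ug/mL with a related large group on its own core, the step from compound 1 to compound 4 in this assay is expected to be small, a 1.5-fold higher number from compound 1 to compound 4 (0.16 log units; within the scatter), toward a slightly higher number. Compound 4 is therefore estimated at 3.5 ug/mL, with a range from 1.5 ug/mL to 8 ug/mL.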

Compound 4, half-maximal inhibitory concentration: > 10 ug/mL
Compound 4: only a limit was reported; the forecaster's own chance of this, stated with the estimate: 5%; at least 2.8-fold (0.45 log units) between middle value and limit.
By their numbers in this assay, from the lowest: compounds 2, 1 and 3 (each within the scatter of the next). At a limit, above all of these: compound 4.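

In this assay, the group on this double-bonded ring carbon of the shared core does matter: (1-carboxy-2-hydroxypropyl)amino in place of methoxy gives an at least 4.1-fold higher number from compound 1 to compound 4 (0.61 log units; beyond the scatter). Compound 4 gives > 10 ug/mL, which is a limit and not a number. The full size of this step therefore stays unknown, and only its smallest possible size can be read: the limit of > 10 ug/mL in this assay, at which 1 of the 4 values shown sits.

What remains open is which part of the new group accounts for this step. A plain amine, or a shorter chain ending in a carboxylic acid, at this position could help separate the contribution of the nitrogen link from that of the rest of the group.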